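Thiocarbamoyl triazole series: oxamate amide replacing aryl methyl

The compounds below may be only part of what the source reports. "The series", "measured", "known", "first", "only" and "open" are said of these compounds alone.

Compound 1 `CNC(=S)n1ncnc1NC` carries a shared core with methylamino groups on both the thioamide and the ring. Compound 2 `C/N=C(\S)n1nc(-c2ccc(C)cc2)nc1N` instead bears a primary amine on the ring and a methyl-substituted aryl group. In a functional assay on the whole organism for inhibition, with Rattus norvegicus as the target, at a dose of 30 mg/kg (on this read-out lower numbers stand for less inhibition and higher numbers for more inhibition at the one dose given (going by the name of the read-out)), compound 1 gives -1% and compound 2 gives 65%; compound 2 stands highest of the two numbers shown, with compound 1 the nearest, beyond the scatter below it.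

Compound 3 `CCOC(=O)C(=O)Nc1ccc(-c2nc(N)n(/C(S)=N/C)n2)cc1` is the next step from compound 2: ((ethoxycarbonyl)carbonyl)amino in place of methyl on an aromatic carbon. Within the data shown here, no measured step of this kind exists among the compounds in hand, so the direction rests on expectation alone. A modest decrease in this assay is expected, of a size that may or may not exceed the scatter, because compound 2 gives 65% and the new group is far larger than the methyl it replaces. The expected step is a number 20 percentage points lower from compound 2 to compound 3 (beyond the scatter). Compound 3 is estimated at 45%, within a range of 10% to 80%.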

Compound 3, a percentage reported as inhibition, in the whole organism at one dose (the size of the read-out at that dose, not a potency): 49%
Compound 3: middle estimate off by 4 percentage points, on the low side; low and high end bracket the measured number.
By their numbers in this assay, from the lowest: compound 1; then compound 3; then compound 2.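

At this aromatic carbon, ((ethoxycarbonyl)carbonyl)amino in place of methyl brings 8 heavy atoms instead of 1, and this assay gives a number 16 percentage points lower from compound 2 to compound 3 (beyond the scatter) as the change. The position therefore accepts a far larger group, one with a hydrogen-bond donor and hydrogen-bond acceptors, and inhibition is not lost: compound 3 still gives 49% at the one dose. This is a single step, so it gives the direction of this one replacement and no trend across substituents.

Still open, going by these compounds, is which part of the new group carries the change: a carboxylic acid in place of the ethyl ester, or a plain amine on the same aromatic carbon, would separate the ester from the amide hydrogen. Nothing measured on these compounds says why the number falls.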